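The source may hold more compounds than are shown below. What is called first, only, known or untested is meant among the compounds shown, and "the series" means these compounds.

In a functional assay on A549 cells (Homo sapiens) for inhibition, read by MTT assay, with a stated time of 48 h (a higher number here means a weaker inhibitor, a lower number a stronger inhibitor), compound 1 `COc1cc(/C=N/Nc2nc(-c3cccc(Br)c3)cs2)cc(Br)c1OC` gives 56000 nM. Compound 3 `COc1cc(/C=N/Nc2nc(-c3cccc(Br)c3)cs2)c(Br)c(Br)c1OC`, at 37000 nM, lies within the scatter of it, while compound 2 `COc1cc(/C=N/Nc2nc(-c3ccccc3)cs2)c(Br)c(Br)c1OC` shows the lowest number of the three, 15300 nM. The step to compound 4 `COc1ccccc1-c1csc(N/N=C/c2cc(Br)c(OC)c(OC)c2)n1` is 2-methoxyphenyl in place of 3-bromophenyl on an aromatic carbon, made on an aromatic carbon of the five-membered aromatic ring. Among the compounds with values here, two measured steps bear on it, and neither involves a methoxy group at this place. The step of a 1.5-fold lower number from compound 1 to compound 3 (0.18 log units; within the scatter) adds a bromo elsewhere in the molecule and so says little about this change. The step of a 2.4-fold higher number from compound 2 to compound 3 (0.38 log units; beyond the scatter) adds the bromo of the 3-bromophenyl group, at the place that changes here, and is the closer guide. Compound 4 also loses that bromo, so a modest move toward the lower number of compound 2, 15300 nM, is expected, though with wide uncertainty. The expected change is a 1.9-fold lower number from compound 1 to compound 4 (0.27 log units; within the scatter). Compound 4 is estimated at 30000 nM, with an expected range from 10000 nM to 75000 nM.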

Compound 4, half-maximal inhibitory concentration: 94900 nM
Compound 4: middle estimate off by 3.2-fold (0.50 log units), on the low side; the measured number lies above the stated range.
By their numbers in this assay, from the lowest: compound 2; then compounds 3, 1 and 4 (each within the scatter of the next, the first and the last beyond it).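

In this assay, putting 2-methoxyphenyl in place of 3-bromophenyl on the aromatic carbon next to the ring nitrogen gives a 1.7-fold higher number from compound 1 to compound 4 (0.23 log units; within the scatter), so this position accepts the exchange on the core of compound 1 without a change beyond the scatter. Within the data shown here, the only earlier step at this place, a 2.4-fold higher number from compound 2 to compound 3 (0.38 log units; beyond the scatter), went beyond the scatter, but it was read on a different core and involved only a bromo, so it did not show how a methoxy-bearing group would behave here. No measurement offered here explains this result.

The step swaps both the bromo and the methoxy at once, so the compounds shown leave their separate contributions open. From the compounds shown here alone, how an amine or a carboxylic acid at this place would read in this assay also remains open.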